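The source may report more compounds than this note shows. Statements on the series, on what has been measured and on what is new or still open speak of the compounds shown alone.

Two hydroxamic acids with a shared core have been measured in an assay on isolated protein for inhibition of protein deacetylase HDAC6 (Homo sapiens), read by fluorescence, with a stated time of 15 min; on this read-out higher numbers stand for weaker inhibition and lower numbers for stronger inhibition. Compound 1 `COc1ccccc1-c1cc(/C=C/c2ccc(C(=O)NO)cc2)ccn1` gives 28 nM in this assay, and compound 2 `Cc1ccc(-c2cc(/C=C/c3ccc(C(=O)NO)cc3)ccn2)cc1` gives 150 nM. Among the compounds with values here, the single step between them, a 5.4-fold higher number from compound 1 to compound 2 (0.73 log units; beyond the scatter), shows that exchanging the aryl group on the core moves the number by a modest but clear amount. Within the data shown here, on the numbers available, compound 2 stands as the higher of the two, with compound 1 as its only neighbour.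

Compound 3 `O=C(NO)c1ccc(/C=C/c2ccnc(-c3ccsc3)c2)cc1` differs from compound 2 in one place: thiophen-3-yl in place of 4-methylphenyl on an aromatic carbon, a thiophen-3-yl in place of 4-methylphenyl on an aromatic carbon. Among the measured compounds shown here, only one measured step bears on such an aryl exchange, and it was of modest size. A step of similar size is therefore plausible in this assay, but its direction cannot be read from the data, since the change from compound 1 to compound 2 involved a different pair of groups. Compound 3 is thus expected to lie near compound 2, with a step of a 1.5-fold lower number from compound 2 to compound 3 (0.18 log units; within the scatter) in either direction being the most likely outcome, so the estimate for compound 3 is 100 nM, ranging from 30 nM to 350 nM.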

Compound 3, half-maximal inhibitory concentration: 54 nM
The estimate for compound 3 lay 1.9-fold (0.27 log units) above the measured number, and the stated range covers the measured number.
By their numbers in this assay, from the lowest: compounds 1 and 3 (each within the scatter of the next); then compound 2.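

The thiophen-3-yl result gives a second exchange at this place, on an aromatic carbon next to the ring nitrogen, in this assay, and it settles the direction the first step could not: there is a 2.8-fold lower number from compound 2 to compound 3 (0.44 log units; beyond the scatter). Against the other aryl group the same exchange gives a 1.9-fold higher number from compound 1 to compound 3 (0.29 log units; within the scatter), so among the three groups shown 4-methylphenyl alone stands apart, with the weakest inhibition, while thiophen-3-yl and 2-methoxyphenyl cannot be told apart, which shows that a six-membered aromatic ring of carbon is not needed at this place for a number as low as that of compound 1. No measurement given here explains why the groups differ in this way.

The compounds shown leave open whether the higher number of compound 2 belongs to the methyl group, to where it sits on the phenyl ring, or to the phenyl ring itself, and a plain phenyl or a 2-methylphenyl group on the same carbon would bear on that. Also open, on these data alone, is how an aryl group carrying an amine or a carboxylic acid would fare at this place.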